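Series notes: microsomal half-life, compound 3 to compound 4

A few compounds are considered here, and "the series" means these few. Any claim that something is new, unique, unknown or untested is made for them only; others in the source may bear on it.

Measured so far in an ADME assay on microsomes from liver (Homo sapiens) for metabolic stability; on this read-out higher numbers stand for a longer-lived compound and lower numbers for a shorter-lived compound:
Compound 1 `COc1cc(OCc2cccc(-c3ccc(C#N)cc3)c2)c2cc(-c3cn4nc(OC)sc4n3)oc2c1` gives > 2 h, which is a limit of the assay and not a number.
Compound 2 `COc1cc(OCc2cccc(-c3ccc(OC)nc3)c2)c2cc(-c3cn4nc(OC)sc4n3)oc2c1` gives 0.733 h.
Compound 3 `COc1ccc(-c2cccc(COc3cc(OC)cc4oc(-c5cn6nc(OC)sc6n5)cc34)c2)nc1` gives 0.767 h.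

Compound 3 has the highest of the two numbers, with compound 2 close by: a 1.0-fold higher number from compound 2 to compound 3 (0.02 log units; within the scatter), so the two cannot be told apart. Replacing the cyanophenyl of compound 1 shortened the half-life in both measured steps, an at least 2.7-fold lower number from compound 1 to compound 2 (0.43 log units; beyond the scatter) and an at least 2.6-fold lower number from compound 1 to compound 3 (0.41 log units; beyond the scatter), each starting from a value that is only a limit (the limit of > 2 h in this assay, at which 1 of the 3 values shown sits).

Compound 4 `COc1cc(OCc2cccc(OCc3ccccc3)c2)c2cc(-c3cn4nc(OC)sc4n3)oc2c1` carries the change (benzyloxy in place of 5-methoxypyridin-2-yl on an aromatic carbon), entering on an aromatic carbon of a six-membered aromatic ring of carbon only, meta to a large group. For the measured compounds named here, no measured step replaces a methoxypyridyl with a benzyloxy, so the closest guidance is the near-identical pair compound 2 and compound 3, which suggests the core with an ether-linked side chain sits around the short end of the range. Compound 4 is therefore expected near compound 3, with a step of a 1.3-fold lower number from compound 3 to compound 4 (0.11 log units; within the scatter) that stays within the scatter. The estimate for compound 4 in this assay is 0.6 h, between 0.3 h and 1.3 h.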

Compound 4, half-life: 1.43 h
Compound 4: middle estimate off by 2.4-fold (0.38 log units), on the low side, outside the stated range (above it).
By their numbers in this assay, from the lowest: compounds 2, 3 and 4 (each within the scatter of the next). At a limit, above all of these: compound 1.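

In this assay, benzyloxy on this aromatic carbon, meta to a large group, stands in for either methoxypyridyl without a step beyond the scatter: a 1.9-fold higher number from compound 3 to compound 4 (0.27 log units; within the scatter), and a 2.0-fold higher number from compound 2 to compound 4 (0.29 log units; within the scatter). The third step, an at least 1.3-fold lower number from compound 1 to compound 4 (0.14 log units; that floor lies within the scatter), starts from compound 1, whose value is a limit and not a number: the limit of > 2 h in this assay, at which 1 of the 4 values shown sits. For the compounds shown here, compound 1 had stood apart from compound 2 and compound 3, but the floor of this step does not separate compound 4 from compound 1, and no step separates compound 4 from compound 2 or compound 3.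

On these data alone, how far compound 4 really lies from compound 1 stays open while compound 1 rests on a limit. Also open, as far as these compounds go, is how an amine or a carboxylic acid carried on this aromatic carbon would read.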